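Compound 4: one more chain carbon on a weak series

The source may hold more compounds than are shown below. What is called first, only, known or untested is meant among the compounds shown, and "the series" means these compounds.

Within the data shown here, in a functional assay on HT-29 cells (Homo sapiens) for inhibition, read by sulforhodamine B assay, with a stated time of 96 h (a higher number here means a weaker inhibitor of growth, a lower number a stronger inhibitor of growth), compound 2 `CC[C@@H](Nc1nc(NCc2ccccn2)c2ncn(C(C)C)c2n1)C(C)O` gives 42000 nM, the only actual number in this small set. Compound 1 `CC[C@@H](Nc1nc(NCc2ccccn2)c2ncn(C(C)C)c2n1)C(C)(C)O` reads > 50000 nM, which is a limit of the assay. Compound 3 `CC[C@H](Nc1nc(NCc2ccccn2)c2ncn(C(C)C)c2n1)C(C)(C)O` reads > 50000 nM, which is also a limit. Thus the picture is dominated by the limit of > 50000 nM in this assay, at which 2 of the 3 values shown sit.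

Compound 4 `CCC(O)[C@H](CC)Nc1nc(NCc2ccccn2)c2ncn(C(C)C)c2n1` differs from compound 2 by 1-ethyl-2-hydroxybutyl in place of 1-(1-hydroxyethyl)propyl on a nitrogen on an aromatic ring. In words, 1-ethyl-2-hydroxybutyl stands in place of 1-(1-hydroxyethyl)propyl on a nitrogen on an aromatic ring.

Among the measured compounds shown here, three measured steps bear on this only loosely. Hydrogen in place of methyl gives an at least 1.1-fold lower number from compound 1 to compound 2 (0.07 log units; that floor lies within the scatter). The swap of side chains gives an at least 1.1-fold higher number from compound 2 to compound 3 (0.07 log units; that floor lies within the scatter). Both floors lie within the scatter, and neither step is the change made here. The configuration change, (the fact that compounds 1 and 3 differ only in the configuration as drawn), gives a step that the two limits leave unreadable from compound 1 to compound 3, so it offers no size to carry over.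

For the measured compounds named here, no measured step therefore supports a shift in either direction in this assay, and compound 4 is expected to stay close to compound 2 at 42000 nM. There is also a real chance that compound 4 will read only as a limit. The estimated step is a 1.1-fold lower number from compound 2 to compound 4 (0.02 log units; within the scatter), which is expected to stay within the scatter. For compound 4 the estimate is 40000 nM, with an expected range from 18000 nM to 80000 nM.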

Compound 4, concentration for 50% growth inhibition: > 50000 nM
Compound 4 was reported as a limit (the forecaster's own chance of this, stated with the estimate: 40%); middle value at least 1.2-fold (0.09 log units) from the limit.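

In this assay compound 4 gives > 50000 nM, which is a limit of the assay and not a number. Placing 1-ethyl-2-hydroxybutyl in place of 1-(1-hydroxyethyl)propyl on a nitrogen on an aromatic ring gives an at least 1.1-fold higher number from compound 2 to compound 4 (0.07 log units; that floor lies within the scatter), so at this position the larger chain does not yield a readable value, and the size of any loss remains unestablished. The steps from compound 1 and compound 3 to compound 4 cannot be read, and the series now rests almost entirely on a single ceiling: the limit of > 50000 nM in this assay, at which 3 of the 4 values shown sit.

With compound 2 the only member carrying an actual number, the compounds shown leave open how far compound 4 really lies from compound 2, and whether any side chain on this nitrogen can give a value well clear of the limit. They also leave open whether an amine or a carboxylic acid in place of the hydroxy group, or a longer chain than 1-ethyl-2-hydroxybutyl, would give a readable number in this assay.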